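The source may hold more compounds than are shown below. What is called first, only, known or untested is meant among the compounds shown, and "the series" means these compounds.

Compound 2 `Oc1ccc(-c2ccc(C(O)c3cccnc3)cc2)cc1` is examined in an assay for inhibition of steroid 17-alpha-hydroxylase/17,20 lyase (Homo sapiens) (a higher number here means a weaker inhibitor, a lower number a stronger inhibitor), where compound 2 gives 4040 nM. Among the two numbers recorded in this assay, compound 2 stands highest. Its nearest neighbour is compound 1 `CCC(c1ccncc1)c1ccc(-c2ccc(OC)cc2)cc1`, which in this assay gives 1610 nM; compound 1 thus sits well to the stronger side of compound 2, and the gap between the two lies beyond the scatter. Compound 1 and compound 2 differ in more than one place, so the two values can only be set side by side, and no single cause can be read from them.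

The step from compound 2 to compound 3 `Oc1ccc(-c2ccc(C(O)c3ccncc3)cc2)cc1` is a smaller one: pyridin-4-yl in place of pyridin-3-yl on a saturated chain carbon bound to an aromatic carbon and an oxygen on a saturated carbon. The two have the same atoms, joined differently. Going by the values given here, no measured pair in this set shows the effect of this change alone, so no step can be quoted for it. The account therefore looks to compound 3 with only a loose expectation: a move toward a lower number in this assay of moderate size, with a real chance that the step stays within the scatter. Compound 3 is estimated to give 2500 nM in this assay, within a range from 800 nM to 8000 nM, an expected step of a 1.6-fold lower number from compound 2 to compound 3 (0.21 log units; within the scatter).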

Compound 3, half-maximal inhibitory concentration: 248 nM
The estimate for compound 3 lay 10-fold (1.00 log units) above the measured number; measured number below the stated range.
By their numbers in this assay, from the lowest: compound 3; then compound 1; then compound 2.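

The exchange of pyridin-3-yl for pyridin-4-yl on a saturated chain carbon bound to an aromatic carbon and an oxygen on a saturated carbon gives a 16-fold lower number from compound 2 to compound 3 (1.21 log units; beyond the scatter) in this assay, so this position proves highly sensitive to how the same atoms are joined within the pyridine ring. The two earlier compounds differ in more than one place and could only be set side by side, whereas here the whole difference belongs to this single exchange, and the step lies beyond the scatter. Nothing at hand offers a measured explanation for why pyridin-4-yl gives the lower number.

As far as these compounds go, it remains open whether the same exchange would give a step of similar size on a different core, such as that of compound 1, which already carries pyridin-4-yl and so has no pyridin-3-yl partner here. Also open, from the compounds shown here alone, is what pyridin-2-yl or an imidazole ring would give at this position, and whether replacing the hydroxyl on the chain carbon with an amine or a methoxy group would keep compound 3 at 248 nM.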